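Swapping Isopropyl for Methylcarbamoyl in a Rat Inhibition Series

A few compounds are considered here, and "the series" means these few. Any claim that something is new, unique, unknown or untested is made for them only; others in the source may bear on it.

Compound 1, `CC1CC/C(=N\Nc2ccc(F)cc2)c2ncc(C(=O)O)c(=O)n21`, in a functional assay on the whole organism for inhibition, with Rattus norvegicus as the target (a lower number here means that less compound is needed, a higher number that more compound is needed for the effect), gives > 1000 umol/kg, which is a limit of the assay.
Compound 2, `CCc1ccc(N/N=C2\CCC(C)n3c2ncc(C(=O)O)c3=O)cc1`, in this assay gives > 1000 umol/kg, again a limit.
Compound 3, `CC(C)c1ccc(N/N=C2\CCC(C)n3c2ncc(C(=O)O)c3=O)cc1`, in this assay gives > 100 umol/kg, also a limit.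

Compound 3 thus stands at a limit, and the two other values shown are limits as well. The steps leading to it, a step that the two limits leave unreadable from compound 1 to compound 3 and a step that the two limits leave unreadable from compound 2 to compound 3, cannot be read in size, since one partner sits at the limit of > 100 umol/kg in this assay, at which 1 of the 3 values shown sits, and the others at the limit of > 1000 umol/kg in this assay, at which 2 of the 3 values shown sit.

Compound 4, `CNC(=O)c1ccc(N/N=C2\CCC(C)n3c2ncc(C(=O)O)c3=O)cc1`, differs from compound 3 in one place: methylcarbamoyl in place of isopropyl on an aromatic carbon. Within the data shown here, none of the measured steps gives a readable size, so nothing here points to a step in either direction beyond the scatter; the most likely outcome is that compound 4 again reaches only a limit.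

Compound 4 is therefore expected to give about 300 umol/kg in this assay, with a range from 60 umol/kg to 3000 umol/kg. This estimate corresponds to a step that the limit leaves unreadable from compound 3 to compound 4.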

Compound 4, dose for 50% inhibition: > 100 umol/kg
Compound 4 ended at the assay's limit (the forecaster's own chance of this, stated with the estimate: 70%); the middle value does not contradict the limit.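

In this assay compound 4 gives > 100 umol/kg, which is a limit of the assay. Its steps from compound 1, compound 2 and compound 3 cannot be read in size. The compounds shown leave open what dose of any of them gives the effect, and whether fluoro, ethyl, isopropyl or methylcarbamoyl makes any difference.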